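Bulkier amine on a dithiocarbamate-bearing chromone

The source may report more compounds than this note shows. Statements on the series, on what has been measured and on what is new or still open speak of the compounds shown alone.

Of the compounds shown here, two have been measured in a functional assay on HeLa cells (Homo sapiens) for antiproliferative activity, read by MTT assay, with a stated time of 72 h; a lower number here means a stronger inhibitor, a higher number a weaker inhibitor. Compound 1 `O=c1c(CSC(=S)N2CCCCC2)coc2cc(Cl)ccc12` carries a piperidine on its thiocarbonyl carbon, and in this assay compound 1 gives 440 nM. Compound 2 `CCN(CC)C(=S)SCc1cc(=O)c2ccc(Cl)cc2o1` shares the chlorinated core but places a diethylamino group on the thiocarbonyl carbon, and in this assay compound 2 gives 8700 nM, the higher of the two numbers and therefore the weaker inhibitor; the gap to compound 1 lies beyond the usual scatter of repeated measurements.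

Compound 3 `CC(C)N(C(=S)SCc1cc(=O)c2ccc(Cl)cc2o1)C(C)C` has not yet been measured. It differs from compound 2 in a single place: diisopropylamino in place of diethylamino on a thiocarbonyl carbon. Both groups are small, uncharged alkyl amines without hydrogen-bond donors or acceptors, so the change is a modest one at the edge of the molecule.

Among the compounds with values here, since no measured pair shows what such a swap does on this core, the expectation rests on the closeness of the two groups. The step of a 1.3-fold lower number from compound 2 to compound 3 (0.13 log units; within the scatter) is expected to stay within the scatter, perhaps leaning slightly toward a lower number. Compound 3 is therefore estimated at 6500 nM, within a range of 1800 nM to 24000 nM.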

Compound 3, half-maximal inhibitory concentration: > 30000 nM
Compound 3: a limit, no number; the forecaster's own chance of this, stated with the estimate: 5%; at least 4.6-fold (0.66 log units) between middle value and limit.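

In this assay, this one change on a thiocarbonyl carbon gives an at least 3.4-fold higher number from compound 2 to compound 3 (0.53 log units; beyond the scatter), the first step shown between compounds that differ in only one place. It shows that the change at this position is not a silent one, even though diethylamino and diisopropylamino match in having no ring, no hydrogen-bond donors or acceptors and no net charge, and differ only in heavy atoms, with 5 leaving and 7 entering. For compound 3 the result is a limit of the assay and not a number: the limit of > 30000 nM in this assay, at which 1 of the 3 values shown sits.

As far as these compounds go, whether a dimethylamino or a morpholine group on the same thiocarbonyl carbon would give a measurable number, and whether the numbers follow the heavy-atom count of the amine at all, stays open. Compound 1 differs from compound 2 in more than one place, so the effect of its piperidine cannot be separated from the other difference, and a piperidine on the shared core of compound 2 and compound 3 would be needed to place that ring alongside these two open-chain amines.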